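The source may report more compounds than this note shows. Statements on the series, on what has been measured and on what is new or still open speak of the compounds shown alone.

Of the compounds shown here, two with a shared core have been measured so far. In a functional assay on MDA-MB-231 cells (Homo sapiens) for inhibition, read by MTT assay, with a stated time of 48 h (on this read-out higher numbers stand for weaker inhibition and lower numbers for stronger inhibition), compound 1 `COc1cc(/C=C/c2ccc(NC(=O)/C=C/c3ccc(C#N)cc3)cc2)cc(OC)c1` gives 7740 nM, and compound 2 `COc1cc(/C=C/c2ccc(NC(=O)/C=C/c3cccc(F)c3)cc2)cc(OC)c1` gives 17300 nM. For the measured compounds named here, compound 2 therefore holds the higher of the two numbers, and compound 1 is its only neighbour: the single measured step, a 2.2-fold higher number from compound 1 to compound 2 (0.35 log units; beyond the scatter), goes with 3-fluorophenyl in place of 4-cyanophenyl on a double-bonded chain carbon bound to a double-bonded chain carbon. Compound 3 `COc1cc(/C=C/c2ccc(NC(=O)/C=C/c3ccc(O)c(O)c3)cc2)cc(OC)c1` has not been measured yet. It differs from compound 2 by 3,4-dihydroxyphenyl in place of 3-fluorophenyl on a double-bonded chain carbon bound to a double-bonded chain carbon. The one measured step bears on this change only loosely: it shows that exchanging one substituted phenyl for another at the same place moved the number modestly, but the 3,4-dihydroxyphenyl group has no measured precedent among these compounds, so the direction of its step is open. A step of roughly similar size, in either direction, is the most that can be expected. Compound 3 is estimated at 10000 nM in this assay, with a range from 3500 nM to 30000 nM. That estimate corresponds to an expected step of a 1.7-fold lower number from compound 2 to compound 3 (0.24 log units; within the scatter).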

Compound 3, half-maximal inhibitory concentration: 4230 nM
Compound 3: the middle estimate sits 2.4-fold (0.37 log units) above what was measured; low and high end bracket the measured number.
By their numbers in this assay, from the lowest: compounds 3 and 1 (each within the scatter of the next); then compound 2.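

In this assay, 3,4-dihydroxyphenyl in place of 3-fluorophenyl on a double-bonded chain carbon bound to a double-bonded chain carbon gives a 4.1-fold lower number from compound 2 to compound 3 (0.61 log units; beyond the scatter), which shows that this place can tolerate a group with hydrogen-bond donors and that the number can fall when 3-fluorophenyl leaves. Exchanging 4-cyanophenyl for 3,4-dihydroxyphenyl gives a 1.8-fold lower number from compound 1 to compound 3 (0.26 log units; within the scatter), so these two groups cannot be ranked, while compound 2, with its 3-fluorophenyl group, is the weakest of the three. Nothing measured here explains why the number changes with these groups.

The compounds shown do not reveal whether both hydroxyl groups of 3,4-dihydroxyphenyl are needed, which a comparison with 3-hydroxyphenyl or 4-hydroxyphenyl at the same place could test, or whether the fluorine's ring position matters, which 4-fluorophenyl could test. They also leave open how a phenyl ring carrying an amine or a carboxylic acid would behave here, and whether the two groups that cannot be ranked in this assay would stay level in any other test.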